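Para-substituent swap on the aryl-oxadiazole of compound 1

This account rests on a few compounds, and the source may have more. Where it says the series, first, only, none or still open, it means among the compounds named here.

Measured compounds:
- compound 1 `CC(C)(C)n1ncc(OCc2nnc(-c3ccc(Br)cc3)o2)c(Cl)c1=O`: 21400 nM
- compound 2 `Cc1cc(C)cc(-c2nnc(COc3cnn(C(C)(C)C)c(=O)c3Cl)o2)c1`: > 299000 nM
- compound 3 `CC(C)(C)n1ncc(OCc2nnc(-c3cccc(F)c3)o2)c(Cl)c1=O`: 7100 nM

In a functional assay on the whole organism for inhibition, with Mythimna separata as the target, with a stated time of 5 days (a lower number here means that less compound is needed, a higher number that more compound is needed for the effect), compound 1 gives 21400 nM, the highest of the two numbers shown; the nearest is compound 3 with 7100 nM. Compound 2 reports only a limit of the assay, > 299000 nM, as recorded in the limit of > 299000 nM in this assay, at which 1 of the 3 values shown sits.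

Compound 4 `CC(C)(C)n1ncc(OCc2nnc(-c3ccc(C(F)(F)F)cc3)o2)c(Cl)c1=O` differs from compound 1 by trifluoromethyl in place of bromo on an aromatic carbon. Two measured steps start from compound 1 and touch the same aryl ring: an at least 13-fold higher number from compound 1 to compound 2 (1.14 log units; beyond the scatter) and a 3.0-fold lower number from compound 1 to compound 3 (0.48 log units; beyond the scatter). Neither step is the change to compound 4, so they bound the question rather than answer it: a change on this ring can push the number beyond the limit or lower it modestly. With no closer comparison, the step in this assay from compound 1 to compound 4 is expected to be small, a 1.1-fold lower number from compound 1 to compound 4 (0.03 log units; within the scatter), with wide uncertainty either way. The estimate for compound 4 is 20000 nM, range 4000 nM to 120000 nM.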

Compound 4, half-maximal effective concentration: 33800 nM
For compound 4 the middle estimate is 1.7-fold (0.23 log units) below the measured one; the measured number falls inside the stated range.
By their numbers in this assay, from the lowest: compound 3; then compounds 1 and 4 (each within the scatter of the next). At a limit, above all of these: compound 2.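

In this assay, trifluoromethyl in place of bromo on an aromatic carbon, para to a large group, gives a 1.6-fold higher number from compound 1 to compound 4 (0.20 log units; within the scatter), so compounds 1 and 4 cannot be told apart at this position even though the entering group has 4 heavy atoms and the leaving one has 1. For the compounds shown here, the earlier steps exchanged one substituted phenyl for another, whereas this one holds the place fixed and replaces only the group, which makes it the first direct reading of this position alone. No measured property available here bears on this step.

Going by these compounds, whether an amine, a carboxylic acid or a longer alkyl chain at this position would also stay within the scatter of compound 1 remains open. On these data alone, it is also open whether the 3-fluorophenyl of compound 3 owes its standing to the fluoro group or to its place on the ring.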